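Halogen swap on the fused benzene ring: chloro to bromo

The source may report more compounds than this note shows. Statements on the series, on what has been measured and on what is new or still open speak of the compounds shown alone.

Among the compounds with values here, compound 3 `Fc1ccc(CNc2nc(Nc3cc(C4CC4)[nH]n3)c3cc(Cl)ccc3n2)c(F)c1` gives the highest of the three numbers measured so far in an assay for inhibition of high affinity nerve growth factor receptor (Homo sapiens), read by HTRF, with a stated time of 30 min, in the presence of a further agent that is not named here (a higher number here means a weaker inhibitor, a lower number a stronger inhibitor), at 72 nM. Its nearest neighbour is compound 2 `Fc1ccc(CNc2nc(Nc3cc(C4CC4)[nH]n3)c3cc(F)ccc3n2)c(F)c1`, which in this assay gives 59 nM; the step of a 1.2-fold higher number from compound 2 to compound 3 (0.09 log units; within the scatter) stays within the scatter. Furthest away is the unsubstituted parent, compound 1 `Fc1ccc(CNc2nc(Nc3cc(C4CC4)[nH]n3)c3ccccc3n2)c(F)c1`, which gives 4.7 nM. Both halogen introductions on that ring cost a lot: a 13-fold higher number from compound 1 to compound 2 (1.10 log units; beyond the scatter) and a 15-fold higher number from compound 1 to compound 3 (1.19 log units; beyond the scatter).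

Compound 4 `Fc1ccc(CNc2nc(Nc3cc(C4CC4)[nH]n3)c3cc(Br)ccc3n2)c(F)c1` carries the next halogen in the same position: bromo in place of chloro on an aromatic carbon. Within the data shown here, the only step that bears directly on this is a 1.2-fold higher number from compound 2 to compound 3 (0.09 log units; within the scatter), which shows that fluoro and chloro sit at the same level within the scatter, and the two steps from compound 1 show that each halogen lowers potency by a similar margin. Among the measured compounds shown here, no step within the halogen series has so far moved the number beyond the scatter, so no step beyond the scatter is expected here either; the expected step is a 1.1-fold higher number from compound 3 to compound 4 (0.05 log units; within the scatter). For compound 4 the expected value in this assay is 80 nM, with a range from 35 nM to 180 nM.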

Compound 4, half-maximal inhibitory concentration: 120 nM
For compound 4 the middle estimate is 1.5-fold (0.18 log units) below the measured one; the measured number falls inside the stated range.
By their numbers in this assay, from the lowest: compound 1; then compounds 2, 3 and 4 (each within the scatter of the next, the first and the last beyond it).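

In this assay the halogen series at this position now holds its first step beyond the scatter, a modest one (a 2.0-fold higher number from compound 2 to compound 4 (0.31 log units; beyond the scatter)), while the neighbouring swap stays within it (a 1.7-fold higher number from compound 3 to compound 4 (0.22 log units; within the scatter)), so chloro cannot be separated from either fluoro or bromo. Bromo also carries the large loss against the hydrogen of the parent (a 26-fold higher number from compound 1 to compound 4 (1.41 log units; beyond the scatter)), so all three halogens here go the same way, with no compound against it. Nothing in the available data bears on the reason for this loss.

Whether the loss is specific to halogens stays open, as the compounds shown pair only halogens with hydrogen here, and a methoxy, an amine or a nitrile at this carbon could answer that. Also open, from the compounds shown here alone, is whether a halogen on the other carbons of this ring costs as much.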